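This account rests on a few compounds, and the source may have more. Where it says the series, first, only, none or still open, it means among the compounds named here.

Measured compounds:
- Compound 1, `CCn1c(C(=O)N(CCC#N)CCC#N)ccc1C(CC)(CC)c1ccc(OCC(=O)C(C)(C)C)c(C)c1`: in an assay on HL-60 cells for agonist activity at vitamin D3 receptor (Homo sapiens), read by microscopy, with a stated time of 96 h (a higher number here means that more compound is needed for the effect, a lower number that less compound is needed), compound 1 gives 870 nM.
- Compound 2, `CCOc1ccc(NC(=O)c2ccc(C(CC)(CC)c3ccc(OCC(=O)C(C)(C)C)c(C)c3)n2CC)cc1`: in this assay compound 2 gives > 50000 nM, which is a limit of the assay and not a number.

Compound 2 therefore stands only at the limit of > 50000 nM in this assay, at which 1 of the 2 values shown sits, so its true value is not pinned down. Among the compounds with values here, the one measured step that touches this part of the molecule is an at least 57-fold higher number from compound 1 to compound 2 (1.75 log units; beyond the scatter), a large loss that came with exchanging the group on the carbonyl carbon.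

Compound 3, `CCn1c(C(=O)OCc2ccc(F)cc2)ccc1C(CC)(CC)c1ccc(OCC(=O)C(C)(C)C)c(C)c1`, differs from compound 2 by (4-fluorobenzyl)oxy in place of (4-ethoxyphenyl)amino on a carbonyl carbon. The new group sits on the same carbonyl carbon that the measured step altered, so the measured step shows that this position can swing the result strongly, but it does not show what the (4-fluorobenzyl)oxy group itself does. Since compound 3 carries neither of the groups compared in the measured step, the direction from the limit is uncertain, though a return toward a measurable value is expected.

For compound 3 the expected step is an at least 10-fold lower number from compound 2 to compound 3 (1.00 log units; beyond the scatter). Compound 3 is estimated at 5000 nM, with a range from 800 nM to 50000 nM.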

Compound 3, half-maximal effective concentration: 9500 nM
Compound 3: the middle estimate sits 1.9-fold (0.28 log units) below what was measured; low and high end bracket the measured number.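

Compound 3 shows that a group carrying a six-membered aromatic ring of carbon only can still give a measurable number on this carbonyl carbon in this assay, which compound 2 alone could not show; exchanging (4-ethoxyphenyl)amino for (4-fluorobenzyl)oxy gives an at least 5.2-fold lower number from compound 2 to compound 3 (0.72 log units; beyond the scatter). The size of that step is only a lower bound because compound 2 stands at a limit of the assay and not at a number: the limit of > 50000 nM in this assay, at which 1 of the 3 values shown sits.

The ring-free group of compound 1 still does better than the (4-fluorobenzyl)oxy group, with an 11-fold higher number from compound 1 to compound 3 (1.04 log units; beyond the scatter), so this exchange recovers only part of the loss seen with compound 2.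

The exchange from compound 2 to compound 3 changes the linking atom, removes the hydrogen-bond donor and replaces the ethoxy-bearing ring with a fluorine-bearing one all at once, so these compounds do not separate the contribution of each change. From the compounds shown here alone, it also remains open whether a (4-fluorobenzyl)amino group or a carboxylic acid on this carbonyl carbon would come closer to compound 1.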